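A few compounds are considered here, and "the series" means these few. Any claim that something is new, unique, unknown or untested is made for them only; others in the source may bear on it.

Measured so far:
Compound 1, `COc1cc(OC)c(-c2nc3cc(/C=C4\SC(=O)NC4=O)ccc3[nH]2)cc1OC`, in a functional assay on MDA-MB-231 cells (Homo sapiens) for inhibition, read by MTT assay, with a stated time of 48 h (on this read-out lower numbers stand for stronger inhibition and higher numbers for weaker inhibition), gives 24500 nM.
Compound 2, `COc1cc(OC)c(-c2nc3cc(/C=C4\SC(=O)N(CC(=O)N5CCCCC5)C4=O)ccc3[nH]2)cc1OC`, in this assay gives > 50000 nM, which is a limit of the assay and not a number.

Compound 2 therefore stands at the limit of this assay, as noted in the limit of > 50000 nM in this assay, at which 1 of the 2 values shown sits, and its true value is not pinned down. Compound 3, `COc1cc(OC)c(-c2nc3cc(/C=C4\SC(=O)N(Cc5cccc(C)c5)C4=O)ccc3[nH]2)cc1OC`, differs from compound 2 by 3-methylphenyl in place of (piperidin-1-yl)carbonyl on a saturated chain carbon bound to an amide-type nitrogen in a ring. Only one measured step exists among these compounds, an at least 2.0-fold higher number from compound 1 to compound 2 (0.30 log units; that floor lies within the scatter), and it concerns the hydrogen on the amide-type nitrogen in the ring being replaced, not an exchange between two substituents already on that nitrogen. It bears on the present step only in showing that compound 2 sits at the limit; it gives no direction for swapping one substituent for another there. The expectation for compound 3 is thus wide: an estimated step of an at least 1.4-fold lower number from compound 2 to compound 3 (0.15 log units; that floor lies within the scatter) in this assay, with no clear direction beyond the scatter. Compound 3 is estimated at 35000 nM, with a range from 8000 nM to 150000 nM.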

Compound 3, half-maximal inhibitory concentration: 1780 nM
Compound 3: the middle estimate sits 20-fold (1.29 log units) above what was measured, outside the stated range (below it).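

In this assay, the amide-type nitrogen in the ring now proves able to carry a substituent with a clear gain in inhibition: 3-methylbenzyl in place of hydrogen gives a 14-fold lower number from compound 1 to compound 3 (1.14 log units; beyond the scatter), whereas the earlier change at this nitrogen showed only a floor within the scatter. The group on the saturated chain carbon bound to that nitrogen also matters, as 3-methylphenyl in place of (piperidin-1-yl)carbonyl gives an at least 28-fold lower number from compound 2 to compound 3 (1.44 log units; beyond the scatter). Compound 2 gives > 50000 nM, which is a limit of the assay and not a number, so the size of that step is a floor only: the limit of > 50000 nM in this assay, at which 1 of the 3 values shown sits.

The compounds shown leave open whether the gain rests on the six-membered aromatic ring itself or needs the methyl group, a question that plain benzyl would address, and whether 2-methylbenzyl or 4-methylbenzyl would read the same. They also leave open how a longer chain between the nitrogen and the ring, or an amine or a carboxylic acid on that ring, would read in this assay.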